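Benzyl for neopentyl at the imidazole substituent of compound 3

The source may report more compounds than this note shows. Statements on the series, on what has been measured and on what is new or still open speak of the compounds shown alone.

Three compounds share one core and differ only in the group on a saturated chain carbon bound to an aromatic carbon. Compound 1 `O=C(O)c1ccccc1-c1ccc(CCc2ncc(CC3CCOCC3)[nH]2)cc1` gives 338 nM in an in vitro functional assay on cells for agonist activity at Bombesin receptor subtype-3 (Homo sapiens), read by luminescence and calcium flux; on this read-out lower numbers stand for an effect already at smaller amounts and higher numbers for an effect only at larger amounts of compound. Compound 2 `O=C(O)c1ccccc1-c1ccc(CCc2ncc(CC3CCCCCC3)[nH]2)cc1` gives 88 nM, and compound 3 `CC(C)(C)Cc1cnc(CCc2ccc(-c3ccccc3C(=O)O)cc2)[nH]1` gives 106 nM. Compound 3 stands second highest of the three, next to compound 2 and well apart from compound 1: the steps read a 3.8-fold lower number from compound 1 to compound 2 (0.58 log units; beyond the scatter), a 3.2-fold lower number from compound 1 to compound 3 (0.50 log units; beyond the scatter) and a 1.2-fold higher number from compound 2 to compound 3 (0.08 log units; within the scatter).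

Compound 4 `Cc1ccc(Cc2cnc(CCc3ccc(-c4ccccc4C(=O)O)cc3)[nH]2)cc1` carries the change (4-methylphenyl in place of tert-butyl on a saturated chain carbon bound to an aromatic carbon). Among the measured compounds shown here, no measured step swaps an alkyl group for an aromatic ring, so the nearest guide is the pair of compound 2 and compound 3, where cycloheptyl and tert-butyl, both built of carbon only, sit within the scatter of each other, while the ring of compound 1, which holds an acceptor, gave the higher number. A carbon-only aromatic ring is therefore expected to behave more like compound 2 and compound 3 than like compound 1, and the step is estimated at a 1.1-fold lower number from compound 3 to compound 4 (0.03 log units; within the scatter). Compound 4 is expected to give about 100 nM, between 30 nM and 350 nM.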

Compound 4, half-maximal effective concentration: 2660 nM
Compound 4: the middle estimate sits 27-fold (1.42 log units) below what was measured; measured number above the stated range.
By their numbers in this assay, from the lowest: compounds 2 and 3 (each within the scatter of the next); then compound 1; then compound 4.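

At this place, on a saturated chain carbon bound to an aromatic carbon, a group built of carbon only can still raise the number sharply: 4-methylphenyl gives large steps against both tert-butyl (a 25-fold higher number from compound 3 to compound 4 (1.40 log units; beyond the scatter)) and cycloheptyl (a 30-fold higher number from compound 2 to compound 4 (1.48 log units; beyond the scatter)). The earlier compounds shown here held saturated groups only and spread modestly, whereas this single six-membered aromatic ring of carbon goes past even oxan-4-yl (a 7.9-fold higher number from compound 1 to compound 4 (0.90 log units; beyond the scatter)), so being carbon-only does not place a group with tert-butyl and cycloheptyl. Nothing available accounts for this jump.

As far as these compounds go, whether the higher number belongs to the aromatic ring itself or to the methyl on it remains open, and an unsubstituted phenyl or a cyclohexyl group here would separate the two. From the compounds shown here alone, how a pyridine ring or an amine at this place would read is also open.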